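Removing a pyrazole methyl from a naphthylthio sulfonylguanidine

This account rests on a few compounds, and the source may have more. Where it says the series, first, only, none or still open, it means among the compounds named here.

The study concerns two measured compounds and one awaiting measurement, all sharing one core. Compound 1 `Cc1cc(-c2ccccc2)n(/C(N)=N/S(=O)(=O)c2cc(C)c(Cl)cc2SCc2cccc3ccccc23)n1` gives 3000 nM in a functional assay on HeLa cells (Homo sapiens) for cytotoxicity, read by MTT assay, with a stated time of 72 h (on this read-out lower numbers stand for stronger inhibition and higher numbers for weaker inhibition), the lowest of the two numbers recorded. Compound 2 `Cc1cc(-c2ccccc2)n(/C(N)=N/S(=O)(=O)c2cc(C)c(Cl)cc2SCc2ccccc2C)n1` gives 160000 nM in this assay, and the step of a 53-fold higher number from compound 1 to compound 2 (1.73 log units; beyond the scatter) comes from exchanging naphthalen-1-yl for 2-methylphenyl on a saturated chain carbon bound to a sulfur.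

Compound 3 `Cc1cc(S(=O)(=O)/N=C(\N)n2nccc2-c2ccccc2)c(SCc2cccc3ccccc23)cc1Cl` differs from compound 1 at a different site: hydrogen in place of methyl on an aromatic carbon. In the wider view this reads as 3-methyl-5-phenyl-1H-pyrazol-1-yl becoming 5-phenyl-1H-pyrazol-1-yl, while the naphthalen-1-yl group that distinguished compound 1 from compound 2 is kept.

Among the measured compounds shown here, no measured step touches this methyl, so the single recorded step gives no direct guide; it shows only that the sulfur-bound side chain matters a great deal. Loss of a lone methyl on an aromatic ring is expected to alter the number little, and compound 3 is estimated at 5000 nM, within 1500 nM to 16000 nM, corresponding to an expected step of a 1.7-fold higher number from compound 1 to compound 3 (0.22 log units; within the scatter) that may stay within the scatter.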

Compound 3, half-maximal inhibitory concentration: 3000 nM
For compound 3 the middle estimate is 1.7-fold (0.22 log units) above the measured one; low and high end bracket the measured number.
By their numbers in this assay, from the lowest: compounds 1 and 3 (each within the scatter of the next); then compound 2.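

In this assay, replacing the methyl of the 3-methyl-5-phenyl-1H-pyrazol-1-yl group with hydrogen gives no change at the digits printed from compound 1 to compound 3 (within the scatter), so with the naphthalen-1-yl group kept, this methyl can be lost without a measurable effect on the read-out. Among the compounds shown here, the earlier compounds gave information only on the sulfur-bound side chain, where the exchange of naphthalen-1-yl for 2-methylphenyl gave a 53-fold higher number from compound 1 to compound 2 (1.73 log units; beyond the scatter); this new step is the first look at the five-membered ring, and it shows that not every small edit to these molecules carries such a large change. Nothing measured here bears on the reason for this flat result.

The compounds shown leave open whether this position would stay as undemanding if it carried something other than methyl or hydrogen, such as an ethyl group, an amine or a carboxylic acid. They also leave open whether the methyl can be lost just as freely when 2-methylphenyl stands on the sulfur-bound chain, since a flat step seen with one side chain need not carry over to another.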